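A Hydroxycyclohexyl Cap on the Amine of Compound 1

This account rests on a few compounds, and the source may have more. Where it says the series, first, only, none or still open, it means among the compounds named here.

Compound 1, `NCCCOc1ccc([C@H]2CC[C@]3(CC2)OOC2(O3)C3CC4CC(C3)CC2C4)cc1`, is followed in an ADME assay on microsomes from liver (Homo sapiens) for metabolic stability, read by LC-MS, tested at 1 uM; on this read-out higher numbers stand for fast clearance and lower numbers for slow clearance. There compound 1 gives < 7 mL.min-1.g-1, which is a limit of the assay rather than a number. Two neighbours frame that position. Compound 2, `CC(C)(O)CN1CCC(Oc2ccc([C@H]3CC[C@]4(CC3)OOC3(O4)C4CC5CC(C4)CC3C5)cc2)CC1`, carries a 1-(2-hydroxy-2-methylpropyl)piperidin-4-yl in place of the 3-aminopropyl on the oxygen of the aromatic ring, and in this assay compound 2 gives 18 mL.min-1.g-1. The result is an at least 2.5-fold higher number from compound 1 to compound 2 (0.41 log units; beyond the scatter). Compound 3, `NCCCCOc1ccc([C@H]2CC[C@]3(CC2)OOC2(O3)C3CC4CC(C3)CC2C4)cc1`, in this assay gives < 7 mL.min-1.g-1, again a limit. Between the two limits the step that the two limits leave unreadable from compound 1 to compound 3 cannot be sized, whereas an at least 2.5-fold lower number from compound 2 to compound 3 (0.41 log units; beyond the scatter) brings the number back to the limit of < 7 mL.min-1.g-1 in this assay, at which 2 of the 3 values shown sit.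

Compound 4, `O[C@H]1CC[C@H](NCCCOc2ccc([C@H]3CC[C@]4(CC3)OOC3(O4)C4CC5CC(C4)CC3C5)cc2)CC1`, differs from compound 1 by 4-hydroxycyclohexyl in place of hydrogen on an amine nitrogen. For the measured compounds named here, none of the measured steps alters the amine nitrogen itself. The closest comparison is the step from compound 1 to compound 2, where replacing the 3-aminopropyl end with a larger group moved the number beyond the scatter and out of the limit. Compound 4 keeps the three-carbon chain of compound 1 and adds a single ring to its nitrogen, so a modest rise is expected rather than a large one. The expected step is an at least 1.4-fold higher number from compound 1 to compound 4 (0.15 log units; that floor lies within the scatter). Compound 4 is therefore estimated at 10 mL.min-1.g-1, between 5 mL.min-1.g-1 and 22 mL.min-1.g-1, in this assay.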

Compound 4, intrinsic clearance in microsomes: < 7 mL.min-1.g-1
Compound 4 was reported as a limit (the forecaster's own chance of this, stated with the estimate: 40%); at least 1.4-fold (0.15 log units) between middle value and limit.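

Adding 4-hydroxycyclohexyl to the amine nitrogen, a place none of the earlier steps touched, leaves compound 4 reported as a limit rather than a number in this assay, so this nitrogen can carry the ring while the read-out stays at the value shared with compound 1 and compound 3: the limit of < 7 mL.min-1.g-1 in this assay, at which 3 of the 4 values shown sit. The steps to compound 4 from compound 1 and from compound 3 each join two limits and cannot be read. For the compounds shown here, the one readable step is an at least 2.5-fold lower number from compound 2 to compound 4 (0.41 log units; beyond the scatter), so a ring carried on the side chain's amine does not by itself bring the higher number seen for compound 2, which remains the only compound of the four with a measured number.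

With limits at both ends, whether 4-hydroxycyclohexyl shifts clearance at all relative to the free amine of compound 1 stays unresolved. Also open, on these data alone, is whether a plain cyclohexyl, or a 2-hydroxy-2-methylpropyl placed directly on this amine nitrogen of the three-carbon chain, would lift the read-out to a measurable number.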